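A few compounds are considered here, and "the series" means these few. Any claim that something is new, unique, unknown or untested is made for them only; others in the source may bear on it.

Of the compounds shown here, three have already been tested in an assay on microsomes from intestine for inhibition of acyl-CoA:cholesterol acyltransferase (Oryctolagus cuniculus); a higher number here means a weaker inhibitor, a lower number a stronger inhibitor. Compound 1 `CCCCCCCCCCC(C)(C)C(=O)Nc1c(O)cc(OC)cc1OC` gives 590 nM in this assay. Compound 2 `CCCCCCCCCCC(C)(C)C(=O)Nc1c(OC)cc(OC)cc1OCC(=O)OC`, in which a (methoxycarbonyl)methyl group replaces a hydrogen on an oxygen on the aromatic ring, gives 2300 nM in this assay; the change is a 3.9-fold higher number from compound 1 to compound 2 (0.59 log units; beyond the scatter). Compound 3 `CCCCCCCCCCC(C)(C)C(=O)Nc1c(OC)cc(OC)cc1OCC(=O)O` carries the free acid, and in this assay compound 3 reaches only the limit > 10000 nM, so no number is known for it. Going from the ester to the acid is an at least 4.3-fold higher number from compound 2 to compound 3 (0.63 log units; beyond the scatter), and from the parent to the acid an at least 16-fold higher number from compound 1 to compound 3 (1.22 log units; beyond the scatter); in both cases the result for compound 3 sits at the limit of > 10000 nM in this assay, at which 1 of the 3 values shown sits.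

Compound 4 `CCCCCCCCCCC(C)(C)C(=O)Nc1c(OC)cc(OC)cc1OCCCCCCC` is not yet measured. It differs from compound 3 by hexyl in place of carboxy on a saturated chain carbon bound to an oxygen on an aromatic ring. The acid that marked the weakest result in this assay is gone, and what remains is a chain on the same oxygen. Because the acid cost an at least 4.3-fold higher number from compound 2 to compound 3 (0.63 log units; beyond the scatter), removing it is expected to recover activity, though the chain in compound 2 still cost a 3.9-fold higher number from compound 1 to compound 2 (0.59 log units; beyond the scatter) relative to compound 1. The step is therefore expected to be an at least 6.6-fold lower number from compound 3 to compound 4 (0.82 log units; beyond the scatter). Compound 4 is estimated to give about 1500 nM in this assay, somewhere between 400 nM and 6000 nM.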

Compound 4, half-maximal inhibitory concentration: 140 nM
For compound 4 the middle estimate is 11-fold (1.03 log units) above the measured one; measured number below the stated range.
By their numbers in this assay, from the lowest: compound 4; then compound 1; then compound 2. At a limit, above all of these: compound 3.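

Compound 2 and compound 3 both carry a chain on this oxygen and both stand higher than compound 1 in this assay, yet a plain heptyl chain goes the other way, with a 4.2-fold lower number from compound 1 to compound 4 (0.62 log units; beyond the scatter). A chain on this oxygen is therefore not costly in itself, and what sits on the chain matters: hexyl in place of methoxycarbonyl gives a 16-fold lower number from compound 2 to compound 4 (1.22 log units; beyond the scatter), and hexyl in place of carboxy gives an at least 71-fold lower number from compound 3 to compound 4 (1.85 log units; beyond the scatter). That last step is only a bound, as compound 3 has a limit and not a number: the limit of > 10000 nM in this assay, at which 1 of the 4 values shown sits.

The compounds shown leave open how the number follows chain length, with a shorter chain such as butyl or a longer chain such as decyl on this oxygen. From the compounds shown here alone, whether an amine at the end of the chain would be tolerated also remains open.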